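Replacing methyl at one chain carbon of compound 3

The source may report more compounds than this note shows. Statements on the series, on what has been measured and on what is new or still open speak of the compounds shown alone.

Measured in a functional assay on the whole organism (strain BALB/c) with Mus musculus as the target, with a stated time of 4 h; a lower number here means that less compound is needed, a higher number that more compound is needed for the effect:
- compound 1 `CC1=C(CN2CC(C(=O)O)C2)CCc2cc(OCCC3CCc4ccccc43)ccc21`: > 1 mg/kg (a limit)
- compound 2 `COc1cc(C)ccc1COc1ccc2c(c1)CCC(CN1CC(C(=O)O)C1)=C2C`: > 0.1 mg/kg (a limit)
- compound 3 `CCc1ccc(COc2ccc3c(c2)CCC(CN2CC(C(=O)O)C2)=C3C)c(OC)c1`: 0.026 mg/kg

Going by the values given here, compound 3, at 0.026 mg/kg, holds the only actual number in this set. The other two values are limits. Compound 4 `COc1cc(CC(C)(C)O)ccc1COc1ccc2c(c1)CCC(CN1CC(C(=O)O)C1)=C2C` carries 1-hydroxy-1-methylethyl in place of methyl on a saturated chain carbon bound to an aromatic carbon.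

The most direct evidence comes from the same place, where methyl in place of hydrogen gave an at least 3.8-fold lower number from compound 2 to compound 3 (0.58 log units; beyond the scatter). Exchanging the whole group, 4-ethyl-2-methoxyphenyl in place of (2,3-dihydro-1H-inden-1-yl)methyl, gave an at least 38-fold lower number from compound 1 to compound 3 (1.58 log units; beyond the scatter). Among the compounds with values here, this place therefore responded beyond the scatter to a small change, but no measured compound carries the entering group, so the size of the next step remains uncertain.

In this assay the expected result is a moderate move towards a higher number, with an estimated 3.1-fold higher number from compound 3 to compound 4 (0.49 log units; beyond the scatter). For compound 4 the estimated value is 0.08 mg/kg, with an expected range from 0.02 mg/kg to 0.4 mg/kg.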

Compound 4, dose for half-maximal effect: 0.16 mg/kg
Estimate against measurement, compound 4: 2.0-fold (0.30 log units) below; the measured number falls inside the stated range.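

In this assay, the change from ethyl to 2-hydroxy-2-methylpropyl reversed the direction seen so far at this chain carbon, giving a 6.2-fold higher number from compound 3 to compound 4 (0.79 log units; beyond the scatter). Going by these compounds alone, the only earlier readable step here, an at least 3.8-fold lower number from compound 2 to compound 3 (0.58 log units; beyond the scatter), had run towards a lower number, so this place does not reward every enlargement of the group and larger replacements can cost activity. Compound 2 carries a limit, so its step to compound 4 cannot be read, and this position has no measured hydrogen-to-1-hydroxy-1-methylethyl comparison: the limit of > 0.1 mg/kg in this assay, at which 1 of the 4 values shown sits.

The compounds shown do not separate the effect of the hydroxyl from that of the added carbons, which a plain 2-methylpropyl at this place would address. As far as these compounds go, whether an amine or a methyl ether there would behave the same way also remains open.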